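A few compounds are considered here, and "the series" means these few. Any claim that something is new, unique, unknown or untested is made for them only; others in the source may bear on it.

In a functional assay on HCT-116 cells (Homo sapiens) for inhibition, read by MTT assay, with a stated time of 48 h (on this read-out higher numbers stand for weaker inhibition and lower numbers for stronger inhibition), compound 1 `COc1cc(-c2cc(-c3ccc(Br)cc3)nc(-c3ccccc3)n2)cc(OC)c1OC`, which carries a 4-bromophenyl group, gives 4320 nM. Compound 2 `COc1cc(-c2cc(-c3cccc([N+](=O)[O-])c3)nc(-c3ccccc3)n2)cc(OC)c1OC`, with a 3-nitrophenyl group, gives > 25000 nM, which is a limit of the assay rather than a number. Compound 3 `COc1cc(-c2cc(-c3ccc(O)cc3)nc(-c3ccccc3)n2)cc(OC)c1OC`, with a 4-hydroxyphenyl group, gives 11900 nM, the higher of the two exact numbers, and compound 1 is its nearest neighbour.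

Compound 4 `COc1cc(-c2cc(-c3cccs3)nc(-c3ccccc3)n2)cc(OC)c1OC` has thiophen-2-yl in place of 4-hydroxyphenyl on an aromatic carbon. Three measured steps change the same part of the molecule: a 2.8-fold higher number from compound 1 to compound 3 (0.44 log units; beyond the scatter), an at least 2.1-fold lower number from compound 2 to compound 3 (0.32 log units; beyond the scatter) and an at least 5.7-fold higher number from compound 1 to compound 2 (0.76 log units; beyond the scatter). All are modest, yet beyond the scatter, so this group does affect the read-out. None of them, however, introduces a five-membered ring, so they give no clear direction for the new change. In this assay, no shift beyond the scatter is therefore expected, and the estimated change is a 1.3-fold lower number from compound 3 to compound 4 (0.12 log units; within the scatter). The estimate for compound 4 is 9000 nM, with an expected range from 3500 nM to 25000 nM.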

Compound 4, half-maximal inhibitory concentration: 17000 nM
Compound 4: the middle estimate sits 1.9-fold (0.28 log units) below what was measured; the range from low to high includes it.
By their numbers in this assay, from the lowest: compound 1; then compounds 3 and 4 (each within the scatter of the next). At a limit, above all of these: compound 2.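

In this assay, replacing the six-membered carbon ring of 4-hydroxyphenyl with the five-membered sulfur-containing ring of thiophen-2-yl, which also removes the hydrogen-bond donor, gives a 1.4-fold higher number from compound 3 to compound 4 (0.15 log units; within the scatter), so this position accepts that change without a clear shift. Thiophen-2-yl does not reach 4-bromophenyl, however, with a 3.9-fold higher number from compound 1 to compound 4 (0.59 log units; beyond the scatter), and compound 1 keeps the lowest number among the compounds shown. Compound 2 gives only a limit, so an at least 1.4-fold lower number from compound 2 to compound 4 (0.16 log units; that floor lies within the scatter) does not fix the true size of that step: the limit of > 25000 nM in this assay, at which 1 of the 4 values shown sits.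

Going by these compounds, it remains open whether a 4-chlorophenyl group would perform like 4-bromophenyl at this position. On these data alone, the effects of an amine or a carboxylic acid on the aromatic ring at this position also remain unknown.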